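Acetylated glycosyl enones: cytotoxicity across aryl variants

The source may hold more compounds than are shown below. What is called first, only, known or untested is meant among the compounds shown, and "the series" means these compounds.

Measured so far:
- compound 1, `CC(=O)OC[C@H]1O[C@@H](CC(=O)/C=C/c2cc(Cl)cc(Cl)c2)[C@H](OC(C)=O)[C@@H](OC(C)=O)[C@@H]1OC(C)=O`: 32.9 nM
- compound 2, `CC(=O)OC[C@H]1O[C@@H](CC(=O)/C=C/c2cc(Cl)cc(Cl)c2O)[C@H](OC(C)=O)[C@@H](OC(C)=O)[C@@H]1OC(C)=O`: "not determined" (no result reported)
- compound 3, `COc1ccc(/C=C/C(=O)C[C@@H]2O[C@H](COC(C)=O)[C@@H](OC(C)=O)[C@H](OC(C)=O)[C@H]2OC(C)=O)cc1OCc1ccccc1`: "not determined" (no result reported)

Within the data shown here, in an ADME assay on cells (Epithelial cell, Homo sapiens) for cytotoxicity, read by MTT assay, with a stated time of 24 h (a higher number here means that more compound is tolerated, a lower number that less compound is tolerated), compound 1 gives 32.9 nM, the only number. Compound 2 stands without a single number in this assay, and compound 3 is the one further entry in the same position, so nothing measured places compound 2 relative to compound 1.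

Compound 4, `CC(=O)OC[C@H]1O[C@@H](CC(=O)/C=C/c2ccc(C(F)(F)F)cc2)[C@H](OC(C)=O)[C@@H](OC(C)=O)[C@@H]1OC(C)=O`, is the next entry for this assay. Its change from compound 2 is 4-(trifluoromethyl)phenyl in place of 3,5-dichloro-2-hydroxyphenyl on a double-bonded chain carbon bound to a double-bonded chain carbon. Among the measured compounds shown here, no step between measured compounds exists for this pair, and with compound 2 lacking a number no size or direction of the step can be read from the data. For the measured compounds named here, the only anchor is compound 1, which shares the core and the ethenyl ketone linker and differs from compound 4 only in the substitution of the aryl ring. The step is therefore expected to be small, without a direction that can be stated, and compound 4 is expected to sit near compound 1.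

In this assay compound 4 is estimated at 40 nM, within 12 nM to 140 nM.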

Compound 4, half-maximal cytotoxic concentration: 103 nM
Compound 4: middle estimate off by 2.6-fold (0.41 log units), on the low side, within the range that was stated.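

In this assay, among these compounds, the aryl group on a double-bonded chain carbon bound to a double-bonded chain carbon gives the first readable step: a 3.1-fold higher number from compound 1 to compound 4 (0.50 log units; beyond the scatter). With the shared core and the linker unchanged, replacing 3,5-dichlorophenyl with 4-(trifluoromethyl)phenyl is enough to shift the number upward, so this position is not indifferent to the aryl substitution. Steps involving compound 2 or compound 3 cannot be read, and nothing measured here bears on the reason for the shift.

This single step removes two chlorines and adds one trifluoromethyl at once, so their separate contributions remain unresolved. Also open, as far as these compounds go, is how the number would respond to an unsubstituted phenyl, a 4-chlorophenyl, or a ring carrying an amine or a carboxylic acid.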